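A few compounds are considered here, and "the series" means these few. Any claim that something is new, unique, unknown or untested is made for them only; others in the source may bear on it.

Measured so far:
Compound 1, `Cc1ccc(NC(=O)Nc2cc(C(C)(C)C)nn2-c2ccccc2)cc1`, gives 4.7 degrees C in an assay on isolated protein for inhibition of serine/threonine-protein kinase 10 (Homo sapiens), read by thermal shift assay, tested at 10 uM; a higher number here means that the compound stabilises the target more against heat, a lower number that the compound stabilises the target less.
Compound 2, `Cn1nc(C(C)(C)C)cc1NC(=O)Nc1cc(C(F)(F)F)cc(C(F)(F)F)c1`, gives 1.1 degrees C in this assay.

Of these two numbers, compound 2 stands lowest, and compound 1 lies above it by a margin beyond the usual scatter. Compound 1 and compound 2 differ from each other in more than one place, so their two values show a gap but not its source.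

Compound 3, `CC(C)(C)c1cc(NC(=O)Nc2cc(C(F)(F)F)cc(C(F)(F)F)c2)n(C(C)(C)C)n1`, is compound 2 with one change: tert-butyl in place of methyl on an aromatic nitrogen. Within the data shown here, no measured pair shows this single change, so there is nothing to tell how far the melting-point shift should move. A change of this kind, swapping one small group for a somewhat larger one at the same spot, is expected to move the shift only a little, in either direction or not beyond the scatter at all. The expected step from compound 2 to compound 3 is a number 0.40 degrees C higher from compound 2 to compound 3 (within the scatter). Compound 3 is therefore estimated at 1.5 degrees C, within a range from -0.5 degrees C to 3.5 degrees C.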

Compound 3, shift of the target's melting temperature: -0.7 degrees C
Estimate against measurement, compound 3: 2.2 degrees C above, and the stated range ends above it.
By their numbers in this assay, from the lowest: compound 3; then compound 2; then compound 1.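

Swapping methyl for tert-butyl on the aromatic nitrogen is the first single change that can be read in this assay, and it gives a number 1.8 degrees C lower from compound 2 to compound 3 (beyond the scatter), a step beyond the scatter. The group on this nitrogen therefore matters to the read-out, and of the two groups compared here, methyl gives the higher number. The data shown offer no measured explanation for this drop.

The two groups alone cannot show whether the number falls steadily as the group grows, or how an ethyl group or a longer chain ending in an amine would behave at this nitrogen. Also unresolved is how much of the higher value of compound 1, at 4.7 degrees C, comes from the group on this nitrogen, as it differs from compound 2 in more than one place.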